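A Phenyl Group Added to Compound 2

The source may hold more compounds than are shown below. What is called first, only, known or untested is meant among the compounds shown, and "the series" means these compounds.

Measured compounds:
Compound 1, `COc1ccc2c(c1)[n+]([O-])nc(NCOC(C)c1ccccc1)[n+]2[O-]`: > 100000 nM
Compound 2, `CCOCNc1n[n+]([O-])c2ccccc2[n+]1[O-]`: 7400 nM

Of the compounds shown here, two have been measured in a functional assay on PC-3 cells (Homo sapiens) for cytotoxicity, read by MTT assay, with a stated time of 72 h; a lower number here means a stronger inhibitor, a higher number a weaker inhibitor. Among the compounds with values here, compound 2 gives 7400 nM, which is the only outright number among the two values shown. Compound 1 gives > 100000 nM, and this is a limit of the assay rather than a number. Compound 1 sits at the limit of > 100000 nM in this assay, at which 1 of the 2 values shown sits. Compound 1 also carries a phenyl group, but it differs from compound 2 in a second place as well, so the two values show only that one is an outright number and the other a limit.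

Compound 3, `CC(OCNc1n[n+]([O-])c2ccccc2[n+]1[O-])c1ccccc1`, has not yet been measured in this assay. It differs from compound 2 by phenyl in place of hydrogen on a saturated chain carbon bound to an oxygen on a saturated carbon and a saturated chain carbon. Within the data shown here, no measured pair of compounds mirrors this single change. The phenyl is nevertheless shared with compound 1, whose value is a limit, so the expectation leans toward weaker inhibition, with the step from compound 2 to compound 3 expected to be clearly beyond the scatter: a 3.4-fold higher number from compound 2 to compound 3 (0.53 log units; beyond the scatter). Compound 3 is therefore expected to give about 25000 nM, within a range from 6000 nM to 100000 nM.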

Compound 3, half-maximal inhibitory concentration: 10700 nM
Beside the measured number, compound 3's estimate is 2.3-fold (0.37 log units) above it; low and high end bracket the measured number.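

In this assay, the phenyl in place of hydrogen on a saturated chain carbon bound to an oxygen on a saturated carbon and a saturated chain carbon can now be read on its own, and the step stays small: a 1.4-fold higher number from compound 2 to compound 3 (0.16 log units; within the scatter). On this evidence, this position accepts a whole aromatic ring without a change that can be told apart from repeat-measurement noise, and the phenyl alone does not account for the gap between compound 1 and compound 2, whereas the other difference, hydrogen in place of methoxy on an aromatic carbon, gives a clear step: an at least 9.3-fold lower number from compound 1 to compound 3 (0.97 log units; beyond the scatter). The value of compound 1 is a limit and not a number, so that step has a known minimum but no known full size: the limit of > 100000 nM in this assay, at which 1 of the 3 values shown sits.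

Still open, as far as these compounds go, is whether a different group on the same saturated chain carbon, such as an amine, a carboxylic acid or a longer chain, would also leave the number unchanged. Also open, from the compounds shown here alone, is whether methoxy on the aromatic carbon would have the same effect in a compound without the phenyl, such as compound 2.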